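The source may report more compounds than this note shows. Statements on the series, on what has been measured and on what is new or still open speak of the compounds shown alone.

Measured compounds:
compound 1 `COC(=O)N1N=C(c2ccccc2)CC1c1cc(OC)c(OC)c(OC)c1` — 6260 nM
compound 2 `COC(=O)N1N=C(c2cccc(O)c2)CC1c1cc(OC)c(OC)c(OC)c1` — 1350 nM
compound 3 `COC(=O)N1N=C(c2ccccc2)CC1c1ccc(OC)c(O)c1` — 3500 nM

In a functional assay on HT-29 cells (Homo sapiens) for antiproliferative activity, read by MTT assay, with a stated time of 48 h (on this read-out higher numbers stand for weaker inhibition of growth and lower numbers for stronger inhibition of growth), compound 2 gives 1350 nM, and compound 1 gives 6260 nM. The difference between them is hydrogen in place of hydroxy on an aromatic carbon, and it produced a 4.6-fold higher number from compound 2 to compound 1 (0.67 log units; beyond the scatter). Compound 3 gives 3500 nM in this assay; the difference between the core of compound 3 and that of compound 2 is not broken down here, so only the two values themselves are shown. Compound 3 and compound 1 lie within the scatter of each other.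

Compound 4 `COC(=O)N1N=C(c2ccccc2)CC1c1ccc(OC)cc1` has not yet been measured in this assay. It differs from compound 3 by hydrogen in place of hydroxy on an aromatic carbon. This is the same kind of change as that from compound 2 to compound 1, though the place is not identical: in compound 3 the hydroxy that leaves sits ortho to a methoxy group and meta to a large group, whereas in compound 2 it sits meta to a large group only. Because a 4.6-fold higher number from compound 2 to compound 1 (0.67 log units; beyond the scatter) was a modest step beyond the scatter, compound 4 is expected to give a higher number than compound 3, estimated as a 2.9-fold higher number from compound 3 to compound 4 (0.46 log units; beyond the scatter), with a little less confidence in size since the surroundings of the place differ. The value of compound 4 in this assay is estimated at 10000 nM, expected to fall between 3500 nM and 30000 nM.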

Compound 4, concentration for 50% growth inhibition: > 10000 nM
Compound 4: no number, only a limit; the forecaster's own chance of this, stated with the estimate: 12%; the middle value sits exactly at the limit.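

In this assay compound 4 gives > 10000 nM, which is a limit of the assay and not a number. Hydrogen in place of hydroxy on an aromatic carbon gives an at least 2.8-fold higher number from compound 3 to compound 4 (0.45 log units; beyond the scatter), so the change moves the number the same way on the second core as it did on the first, a 4.6-fold higher number from compound 2 to compound 1 (0.67 log units; beyond the scatter). The direction therefore carries over between these two cores, but this pair does not show that the size of the step carries over as well: the same change on two cores in this assay, a 4.6-fold higher number (0.67 log units; beyond the scatter) from compound 2 to compound 1 and an at least 2.8-fold higher number (0.45 log units; beyond the scatter) from compound 3 to compound 4; the limit leaves it open whether they differ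

The compounds shown leave open what an amine or a fluorine atom would do on the aromatic carbon that carries the hydroxy in compound 2 or compound 3, since hydrogen is the only replacement seen here. They also leave open whether the step would hold on a core where the methoxy group ortho to that carbon gives way to a longer chain such as ethoxy, and whether it would carry over to any cell line other than the one in this assay.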